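Pyridin-2-yl in Place of 1,3-Benzothiazol-2-yl on the Amide

This account rests on a few compounds, and the source may have more. Where it says the series, first, only, none or still open, it means among the compounds named here.

Compound 3 `O=C(Cn1c(-c2ccccc2)cc(-c2ccccc2)c1-c1ccc(Br)cc1)Nc1nc2ccccc2s1` gives 86.7% in an ADME assay on HEK-293T cells (Homo sapiens) for cytotoxicity, read by MTT assay, with a stated time of 72 h, tested at 50 uM (a lower number here means less inhibition, a higher number more inhibition at the concentration tested (going by the name of the read-out)), the highest of the three measured numbers. Within the data shown here, compound 1 `O=C(Cn1c(-c2ccccc2)cc(-c2ccccc2)c1-c1ccco1)Nc1ccccn1` gives 69.4% and compound 2 `O=C(Cn1c(-c2ccccc2)cc(-c2ccccc2)c1-c1ccccc1)Nc1ccccn1` gives 62.9%; the single measured step, a number 6.5 percentage points lower from compound 1 to compound 2 (within the scatter), lies within the scatter. Compound 4 `O=C(Cn1c(-c2ccccc2)cc(-c2ccccc2)c1-c1ccc(Br)cc1)Nc1ccccn1` differs from compound 3 in one place: pyridin-2-yl in place of 1,3-benzothiazol-2-yl on an amide-type nitrogen. Among the measured compounds shown here, no measured step alters this group on the amide-type nitrogen, so the measured step does not bear on it. Compounds 1 and 2 carry the pyridin-2-yl group and sit lower than compound 3, which carries the 1,3-benzothiazol-2-yl group, though they also differ elsewhere. The expected step is a number 18.7 percentage points lower from compound 3 to compound 4 (beyond the scatter), a fall beyond the scatter. Compound 4 is expected to give 68%, between 55% and 82%.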

Compound 4, a percentage reported as inhibition, at one concentration (the size of the read-out at that concentration, not a potency): 75%
Compound 4: the middle estimate sits 7 percentage points below what was measured; measured number inside the range.
By their numbers in this assay, from the lowest: compounds 2, 1 and 4 (each within the scatter of the next, the first and the last beyond it); then compound 3.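

In this assay, the change on the amide-type nitrogen now has a direct measure: a number 11.7 percentage points lower from compound 3 to compound 4 (beyond the scatter). With pyridin-2-yl kept there, bromo in place of hydrogen on an aromatic carbon gives a number 12.1 percentage points higher from compound 2 to compound 4 (beyond the scatter), while 4-bromophenyl in place of furan-2-yl on an aromatic carbon gives a number 5.6 percentage points higher from compound 1 to compound 4 (within the scatter), so that swap does not separate the two compounds. No available measurement gives a reason for these steps.

On these data alone, how a simple phenyl or a methyl on the amide-type nitrogen would read remains open. So does whether the benzothiazolyl-to-pyridinyl step keeps its size with furan-2-yl or plain phenyl on the core.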